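Ortho-substituent swap on the thiourea and amide aryl rings

The compounds below may be only part of what the source reports. "The series", "measured", "known", "first", "only" and "open" are said of these compounds alone.

Compound 1 `NC(=O)c1c(NC(=O)c2ccccc2Cl)sc2c1CCN(C(=S)Nc1ccccc1Br)C2` gives 10800 nM in a functional assay on MKN-74 cells (Homo sapiens) for antiproliferative activity, with a stated time of 24 h; a higher number here means a weaker inhibitor, a lower number a stronger inhibitor. Compound 2 `NC(=O)c1c(NC(=O)c2ccccc2Cl)sc2c1CCN(C(=S)Nc1ccccc1C(F)(F)F)C2` gives 1870 nM in this assay. The change between them, (trifluoromethyl in place of bromo on an aromatic carbon), produced a 5.8-fold lower number from compound 1 to compound 2 (0.76 log units; beyond the scatter).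

Compound 3 `NC(=O)c1c(NC(=O)c2ccccc2Br)sc2c1CCN(C(=S)Nc1ccccc1F)C2` has only a limit in this assay, > 50000 nM. This is the limit of > 50000 nM in this assay, at which 1 of the 3 values shown sits. The difference between the core of compound 3 and the core of compound 1 is not broken down here.

Compound 4 `NC(=O)c1c(NC(=O)c2ccccc2C(F)(F)F)sc2c1CCN(C(=S)Nc1ccccc1F)C2` is not yet measured. It differs from compound 3 by trifluoromethyl in place of bromo on an aromatic carbon. The place line matches that of the earlier change word for word, so this is the same change; cut one bond further out it reads 2-bromophenyl to 2-(trifluoromethyl)phenyl, whereas the earlier one also reads (2-bromophenyl)amino to (2-(trifluoromethyl)phenyl)amino.

The expected step from compound 3 to compound 4 is an at least 2.0-fold lower number from compound 3 to compound 4 (0.30 log units; that floor lies within the scatter), resting on a 5.8-fold lower number from compound 1 to compound 2 (0.76 log units; beyond the scatter) and on the limit of compound 3. Compound 4 is estimated at 25000 nM, between 6000 nM and 60000 nM, with a fair chance that only a limit is again returned.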

Compound 4, half-maximal inhibitory concentration: 19600 nM
Compound 4: the middle estimate sits 1.3-fold (0.11 log units) above what was measured, and the stated range covers the measured number.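

In this assay, trifluoromethyl in place of bromo on an aromatic carbon gives an at least 2.5-fold lower number from compound 3 to compound 4 (0.40 log units; beyond the scatter), so the lower number seen on the core of compound 1 recurs in the same direction on the core of compound 3. Set side by side, the two steps agree in direction, but they cannot be ranked by size: the same change on two cores in this assay, a 5.8-fold lower number (0.76 log units; beyond the scatter) from compound 1 to compound 2 and an at least 2.5-fold lower number (0.40 log units; beyond the scatter) from compound 3 to compound 4; the limit leaves it open whether they differ. As far as these compounds go, compound 3 stands only as a limit, and two cores make no rule for the whole series, so the full size of the second step stays unknown: the limit of > 50000 nM in this assay, at which 1 of the 4 values shown sits.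

The compounds shown leave open whether a methyl, a methoxy or a nitrile in place of bromo would follow the same direction, and whether an amine or a carboxylic acid at that place would do so as well. Also open, from the compounds shown here alone, is whether the step would carry over to an analogue with a urea in place of the thiourea.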